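Swapping the piperazine substituent: from enamine to methylbenzyl

The source may report more compounds than this note shows. Statements on the series, on what has been measured and on what is new or still open speak of the compounds shown alone.

Compound 1 `Cn1cnnc1SCC(=O)Nc1ccc(-c2nc(-c3ccccc3)c(-c3ccccc3)n2C)cc1` and compound 2 `CN(C)/C=C/N1CCN(CC(=O)Nc2ccc(-c3nc(-c4ccccc4)c(-c4ccccc4)n3C)cc2)CC1` share one core and differ only at the saturated chain carbon bound to the carbonyl carbon. In a functional assay on HT-29 cells (Homo sapiens) for cytotoxicity, read by MTT assay, with a stated time of 24 h, tested at 1.6 ug/mL (on this read-out lower numbers stand for a weaker effect and higher numbers for a stronger effect at the one concentration tested), compound 1 gives 40.8%, while compound 2 gives 8%. Compound 2 thus stands lowest of the two numbers shown, and the one measured step, a number 32.8 percentage points lower from compound 1 to compound 2 (beyond the scatter), is large.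

Compound 3 `Cc1ccc(CN2CCN(CC(=O)Nc3ccc(-c4nc(-c5ccccc5)c(-c5ccccc5)n4C)cc3)CC2)cc1` follows from compound 2 by the change (4-methylbenzyl in place of 2-(dimethylamino)ethenyl on an amine nitrogen in a ring). This alters only the group on the ring nitrogen, whereas the step from compound 1 to compound 2 exchanged the whole group on the chain carbon; that step therefore bears on the present one only indirectly, by showing that changes at this end of the molecule can move the read-out far. For the measured compounds named here, no measured pair tests a methylbenzyl group here, so the direction is uncertain. A moderate rise is expected for compound 3, a number 14 percentage points higher from compound 2 to compound 3 (beyond the scatter), because compound 1 with its ring-bearing group on the same chain carbon gave 40.8%. Compound 3 is therefore estimated at 22%, within a range from 5% to 50%.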

Compound 3, a percentage reported as activity, at one concentration (the size of the read-out at that concentration, not a potency): 26.4%
Compound 3: middle estimate off by 4.4 percentage points, on the low side; the range from low to high includes it.
By their numbers in this assay, from the lowest: compound 2; then compound 3; then compound 1.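

In this assay, a number 18.4 percentage points higher from compound 2 to compound 3 (beyond the scatter), so with the piperazine kept in place, the group on the ring nitrogen alone is enough to shift the read-out beyond the usual scatter. The earlier step had replaced the entire group on the chain carbon and could not isolate this ring nitrogen as a place where the read-out responds. No measurement here explains why 4-methylbenzyl gives the higher number than 2-(dimethylamino)ethenyl.

This single swap removes a double bond and a nitrogen and adds an aromatic ring, so the compounds shown cannot say which of these differences matters, and a plain benzyl group without the methyl, or a simple ethyl group on the same nitrogen, would help to separate them. Also open, on these data alone, is whether any group on this nitrogen can close the distance between compound 3 at 26.4% and compound 1 at 40.8%, and, with only one concentration tested, whether these numbers would hold as a ranking of potency.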